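The source may report more compounds than this note shows. Statements on the series, on what has been measured and on what is new or still open speak of the compounds shown alone.

Three compounds have values so far in a physicochemical assay for solubility, with a stated time of 24 h, tested at 30 mg/mL (a higher number here means a more soluble compound, a lower number a less soluble compound), so far:

Compound 1 `CC(=O)N1CC(CC(=O)NO)(NS(=O)(=O)c2ccc(OCc3cc(C)nc4ccccc34)cc2C)C1` gives 900000 nM
Compound 2 `Cc1cc(COc2ccc(S(=O)(=O)NCCC(=O)NO)cc2)c2ccccc2n1` gives 4100000 nM
Compound 3 `Cc1cc(COc2ccc(S(=O)(=O)NC3(CC(=O)NO)CN(CCC(F)(F)F)C3)cc2)c2ccccc2n1` gives 3400000 nM

Compound 3 (3400000 nM) stands level with compound 2 within the usual scatter of repeated measurements, while compound 1 lies lower than compound 3 by more than that scatter.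

Still unmeasured is compound 4 `Cc1cc(COc2ccc(S(=O)(=O)NC3(CC(=O)NO)CN(C(=O)C(C)(C)N(C)C)C3)cc2)c2ccccc2n1` which differs from compound 3 in one place: (1-(dimethylamino)-1-methylethyl)carbonyl in place of 3,3,3-trifluoropropyl on an amine nitrogen in a ring. That nitrogen sits in a four-membered non-aromatic ring, which also bears a (hydroxycarbamoyl)methyl group.

Among the measured compounds shown here, no two measured compounds differ in just one place, so no measured step shows what a swap like this does. For the measured compounds named here, the only guide is the spread of values, from compound 1 (900000 nM) to compound 2 (4100000 nM), and compound 4 is expected to land near or somewhat past the top of it. The estimated change is a modest rise (a 2.2-fold higher number from compound 3 to compound 4 (0.34 log units; beyond the scatter)), only slightly beyond the scatter, and its direction is a judgement with little support. The expected value for compound 4 is 7500000 nM (estimated range 1500000 nM to 40000000 nM).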

Compound 4, solubility: 11000000 nM
Compound 4: middle estimate off by 1.5-fold (0.17 log units), on the low side; low and high end bracket the measured number.
By their numbers in this assay, from the lowest: compound 1; then compounds 3 and 2 (each within the scatter of the next); then compound 4.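

Among the compounds shown here, compound 3 and compound 4 give the first direct reading of what the group on the amine nitrogen of the four-membered ring can do. In this assay, (1-(dimethylamino)-1-methylethyl)carbonyl in place of 3,3,3-trifluoropropyl gives a 3.2-fold higher number from compound 3 to compound 4 (0.51 log units; beyond the scatter) and so moves the number by more than repeat measurements would, even though the step is modest and the rest of the molecule is unchanged. Nothing measured here gives a reason for this rise.

The entering group differs from the leaving one in several ways at once, as it adds a carbonyl and a dimethylamino nitrogen and removes the fluorines, so this single step cannot show which of these changes goes with the higher number. On these data alone, a pivaloyl group, which keeps the carbonyl without the amine, or a 3-(dimethylamino)propyl chain, which keeps the amine without the carbonyl, would help to separate those parts, and it remains open whether the same swap gives a similar step on a different core.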